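The source may hold more compounds than are shown below. What is called first, only, known or untested is meant among the compounds shown, and "the series" means these compounds.

Among the measured compounds shown here, compound 3 `Cc1nc2c3ccccc3ccc2c2nc3c(ccc4ccccc43)c(C)c12` gives 195 ug/mL in a functional assay, with a stated time of 90 s (on this read-out lower numbers stand for stronger inhibition and higher numbers for weaker inhibition), the highest of the three numbers measured so far, though it lies within the scatter of both other compounds. Compound 1 `Cc1ccc(-c2c3ccc4ccccc4c3nc3c2c(C)nc2c4ccccc4ccc32)cc1` gives 192 ug/mL, and compound 2 `Cc1nc2c3ccccc3ccc2c2nc3c(ccc4ccccc43)c(-c3cccc([N+](=O)[O-])c3)c12` gives 157 ug/mL. Compound 4 `Cc1nc2c3ccccc3ccc2c2nc3c(ccc4ccccc43)c(-c3cccc4ccccc34)c12` has not yet been measured. It differs from compound 3 in one place: naphthalen-1-yl in place of methyl on an aromatic carbon. For the measured compounds named here, two measured steps bear on this change, since each exchanges an aromatic group for methyl on the same aromatic carbon: a 1.0-fold higher number from compound 1 to compound 3 (0.01 log units; within the scatter) and a 1.2-fold higher number from compound 2 to compound 3 (0.09 log units; within the scatter). Neither moved the read-out beyond the scatter, so swapping methyl for an aromatic group at this carbon has so far made no visible difference. Naphthalen-1-yl brings two six-membered aromatic rings rather than the single ring of 4-methylphenyl or 3-nitrophenyl, and no measured compound shows what such a group does here. For compound 4 the expected step is a 1.1-fold lower number from compound 3 to compound 4 (0.02 log units; within the scatter), no change beyond the scatter. Compound 4 is estimated to give 185 ug/mL, within a range from 95 ug/mL to 370 ug/mL.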

Compound 4, half-maximal inhibitory concentration: 179 ug/mL
Estimate against measurement, compound 4: 1.0-fold (0.01 log units) above, and the stated range covers the measured number.
By their numbers in this assay, from the lowest: compounds 2, 4, 1 and 3 (each within the scatter of the next).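

The step of a 1.1-fold lower number from compound 3 to compound 4 (0.04 log units; within the scatter) in this assay shows that even a group with two aromatic rings, placed on this carbon opposite the ring nitrogen, leaves the read-out where methyl left it. The comparisons with the single-ring groups agree, with a 1.1-fold higher number from compound 2 to compound 4 (0.06 log units; within the scatter) and a 1.1-fold lower number from compound 1 to compound 4 (0.03 log units; within the scatter) both showing no real change. So all four groups shown at this carbon, from methyl to naphthalen-1-yl, read alike, and no measurement here offers a reason for that.

Going by these compounds, what remains open is whether a group of a different kind at this carbon, such as an amine or a carboxylic acid, would shift the number beyond the scatter. Also open, on these data alone, is whether changing the shared core elsewhere, for instance replacing its other methyl with a longer chain, would matter more.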